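Oxime replacement on the enone carbon of a macrocyclic series

The source may report more compounds than this note shows. Statements on the series, on what has been measured and on what is new or still open speak of the compounds shown alone.

Measured compounds:
- compound 1 `CC(C)=CCC[C@]1(C)/C=C/[C@@H](OC(=O)C=C(C)C)[C@](C)(O)/C=C/C(=O)/C(CN(C)C)=C\C1`: 480 nM
- compound 2 `CC(C)=CCC[C@]1(C)/C=C/[C@@H](OC(=O)C=C(C)C)[C@](C)(O)CCC(=O)/C(CO)=C\C1`: > 40000 nM
- compound 3 `CC(C)=CCC[C@]1(C)/C=C/[C@@H](OC(=O)C=C(C)C)[C@](C)(O)/C=C/[C@H](O)/C(CO)=C\C1`: > 40000 nM

Among the compounds with values here, in a functional assay on SW480 cells (Homo sapiens) for antiproliferative activity, read by MTT assay, with a stated time of 48 h (a lower number here means a stronger inhibitor, a higher number a weaker inhibitor), compound 1 gives 480 nM and is the only compound of the three with a numerical value. For compound 2 the assay reports only a limit, > 40000 nM. For compound 3 likewise only a limit is reported, > 40000 nM. Within the data shown here, two of the three results therefore sit at the limit (the limit of > 40000 nM in this assay, at which 2 of the 3 values shown sit), so compound 1 stands alone as the one measurable inhibitor and no step between measured compounds can be sized.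

Compound 4 `CO/N=C/C1=C/C[C@](C)(CCC=C(C)C)/C=C/[C@@H](OC(=O)C=C(C)C)[C@](C)(O)/C=C/C1=O` keeps the core of compound 1 and differs at one place: a group of 4 heavy atoms (2 carbon, 1 nitrogen, 1 oxygen; no ring) in place of a group of 4 heavy atoms (3 carbon, 1 nitrogen; no ring), on a double-bonded ring carbon. The double-bonded ring carbon that carried the (dimethylamino)methyl group in compound 1 now carries the new group, while the rest of the ring and its substituents are unchanged.

Among the measured compounds shown here, with no measured step to lean on, the size of the step is uncertain. The expectation is a loss of potency beyond the usual scatter, with the step from compound 1 to compound 4 estimated at a 4.2-fold higher number from compound 1 to compound 4 (0.62 log units; beyond the scatter). Compound 4 is accordingly expected to give about 2000 nM in this assay, within the range 400 nM to 12000 nM, with a real chance that only a limit is returned.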

Compound 4, half-maximal inhibitory concentration: 2630 nM
For compound 4 the middle estimate is 1.3-fold (0.12 log units) below the measured one, and the stated range covers the measured number.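

In this assay, exchanging the (dimethylamino)methyl group for the oxime group on the double-bonded ring carbon gives a 5.5-fold higher number from compound 1 to compound 4 (0.74 log units; beyond the scatter). Within the data shown here, this is the first measured step at this position, and it shows that the (dimethylamino)methyl group is not needed for a measurable value on the core of compound 1, although the exchange does cost potency. Both groups have the same count of heavy atoms, and compound 4 still returns a number rather than joining the values held at the assay limit: the limit of > 40000 nM in this assay, at which 2 of the 4 values shown sit.

Among these compounds, a single pair cannot separate the loss of the (dimethylamino)methyl group from the entry of the oxime group, and no step to a compound with only a limit can be read. A pyrrolidin-1-ylmethyl or primary aminomethyl group on this carbon, or a longer alkyl chain on the oxime oxygen, would show whether the amine nitrogen or the size of the group tracks with the value in this assay.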